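Removing a Methyl: Cytotoxicity on a Shared Core

The compounds below may be only part of what the source reports. "The series", "measured", "known", "first", "only" and "open" are said of these compounds alone.

Three compounds share a long arm ending in a trifluoromethoxy-substituted ring and differ in the fused core at the other end. Compound 1 `Cc1ccc2[nH]c(C)c(C(=O)NCc3ccc(N4CCC(c5ccc(OC(F)(F)F)cc5)CC4)cc3)c2c1` and compound 2 `Cc1nn2ccc(=O)[nH]c2c1C(=O)NCc1ccc(N2CCC(c3ccc(OC(F)(F)F)cc3)CC2)cc1` carry two such cores, yet in a toxicity assay on Vero cells (Chlorocebus sabaeus) for cytotoxicity, read by CCK-8 assay, with a stated time of 72 h (a lower number here means a stronger inhibitor, a higher number a weaker inhibitor), compound 1 gives "not determined" (no result reported) and compound 2 gives "not determined" (no result reported). Only compound 3 `Cc1cn2nc(C)c(C(=O)NCc3ccc(N4CCC(c5ccc(OC(F)(F)F)cc5)CC4)cc3)c2s1` has a result. In this assay, among the compounds with values here, compound 3 reaches > 100000 nM, which is a limit of the measurement and not a number; this is the case described by the limit of > 100000 nM in this assay, at which 1 of the 3 values shown sits, so compound 3 stands as the only compound with any reading at all.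

Compound 4 `Cc1nn2ccsc2c1C(=O)NCc1ccc(N2CCC(c3ccc(OC(F)(F)F)cc3)CC2)cc1` differs from compound 3 by hydrogen in place of methyl on an aromatic carbon. Within the data shown here, no comparable pair of measured compounds exists here, so no measured step is available. The step of a number no higher from compound 3 to compound 4 (the limit leaves the size open) is expected to show no change beyond the scatter. Compound 4 is expected to give 100000 nM, with a range from 50000 nM to 200000 nM, most likely again as a limit.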

Compound 4, half-maximal inhibitory concentration: > 100000 nM
Compound 4: a limit, no number (the forecaster's own chance of this, stated with the estimate: 85%); the middle value lies on the limit itself.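

No step can be read from compound 3 to compound 4, because both results are limits of the measurement and not numbers: the limit of > 100000 nM in this assay, at which 2 of the 4 values shown sit.

The compounds shown leave open whether hydrogen in place of methyl on an aromatic carbon changes the result in this assay at all.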